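This account rests on a few compounds, and the source may have more. Where it says the series, first, only, none or still open, it means among the compounds named here.

Three close relatives of one scaffold have been measured in a functional assay on MCF7 cells (Homo sapiens) for antiproliferative activity, read by MTT assay, with a stated time of 48 h; on this read-out lower numbers stand for stronger inhibition and higher numbers for weaker inhibition. Compound 1 `COc1ccc(-c2nnc(NC(=O)/C=C/c3ccc(F)cc3)s2)cc1` gives 0.85 ug/mL in this assay. Compound 2 `O=C(/C=C/c1ccc(F)cc1)Nc1nnc(-c2ccccc2)s1` lacks one group of compound 1. In this assay compound 2 gives 1.45 ug/mL. Compound 3 `O=C(/C=C/c1ccccc1)Nc1nnc(-c2ccc(Cl)cc2)s1` has a different core from compound 2. In this assay compound 3 gives 1.42 ug/mL; the difference between the two cores is not broken down here, and their two numbers lie within the scatter of each other, so nothing can be said about an order between compound 2 and compound 3.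

Among the compounds with values here, the only step that can be counted runs from compound 2 to compound 1: a 1.7-fold lower number from compound 2 to compound 1 (0.23 log units; within the scatter). The structural change behind it is methoxy in place of hydrogen on an aromatic carbon.

The unmeasured compound 4 `COc1ccc(/C=C/C(=O)Nc2nnc(-c3ccc(Cl)cc3)s2)cc1` carries the same change on the core of compound 3: methoxy in place of hydrogen on an aromatic carbon. Within the data shown here, the two changes sit at the same kind of place, so the step from compound 2 to compound 1 is the only guide to what compound 4 might do. Since that step stayed within the scatter, a similarly modest shift is expected from compound 3 to compound 4 in this assay, a 1.6-fold lower number from compound 3 to compound 4 (0.20 log units; within the scatter), resting on compound 3 at 1.42 ug/mL and on the step already seen. On that basis compound 4 is estimated at 0.9 ug/mL in this assay, most likely between 0.5 ug/mL and 1.8 ug/mL.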

Compound 4, half-maximal inhibitory concentration: 0.91 ug/mL
Compound 4: middle estimate off by 1.0-fold (0.00 log units), on the low side; the measured number falls inside the stated range.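

In this assay, methoxy in place of hydrogen on an aromatic carbon gives a 1.6-fold lower number from compound 3 to compound 4 (0.19 log units; within the scatter), a shift as small as the one seen earlier on the other core. Set side by side, the two steps match closely: the same change on two cores in this assay, a 1.7-fold lower number (0.23 log units; within the scatter) from compound 2 to compound 1 and a 1.6-fold lower number (0.19 log units; within the scatter) from compound 3 to compound 4, 1.1-fold (0.04 log units) apart, within the scatter of two such steps. This shows that the change behaved alike on the two cores, so the earlier step was a fair guide here, but each step on its own lies within the scatter, so neither shows that methoxy truly changes the antiproliferative read-out, and two pairs make no rule for the whole series.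

What the compounds shown leave open is whether a different group at the same place, such as a hydroxyl, an amine, a carboxylic acid or a longer chain like ethoxy, would give a step that clears the scatter. Within the data shown here, also open is what the fluoro and chloro groups contribute on their own, since compound 2 and compound 3 differ in more than one place and no pair here isolates either group.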